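Pyridinone series: carbonyl-to-sulfonyl swap at the amine

A few compounds are considered here, and "the series" means these few. Any claim that something is new, unique, unknown or untested is made for them only; others in the source may bear on it.

Measured compounds:
compound 1 `CCCCc1ccc(CNC(=O)OC(C)(C)C)c(=O)n1Cc1ccc(-c2ccccc2-c2nn[nH]n2)cc1` — 10 nM
compound 2 `CCCCc1ccc(CN)c(=O)n1Cc1ccc(-c2ccccc2-c2nn[nH]n2)cc1` — 20 nM
compound 3 `CCCCc1ccc(CNC(=O)N(C)C)c(=O)n1Cc1ccc(-c2ccccc2-c2nn[nH]n2)cc1` — 2 nM

Three compounds share one core and differ only in what sits on the aminomethyl nitrogen. In a functional assay (aorta) for antagonist activity, with Oryctolagus cuniculus as the target (a lower number here means a stronger inhibitor, a higher number a weaker inhibitor), compound 3 gives the lowest number of the three, with compound 1 nearest and compound 2 furthest. The measured steps are a 2.0-fold higher number from compound 1 to compound 2 (0.30 log units; within the scatter), a 5.0-fold lower number from compound 1 to compound 3 (0.70 log units; beyond the scatter) and a 10-fold lower number from compound 2 to compound 3 (1.00 log units; beyond the scatter). Compound 4 `CCCCc1ccc(CNS(C)(=O)=O)c(=O)n1Cc1ccc(-c2ccccc2-c2nn[nH]n2)cc1` is not yet measured; it differs from compound 3 by methylsulfonyl in place of dimethylcarbamoyl on an amine nitrogen. Among the measured compounds shown here, the steps that bear on this are those in which the substituent on the amine nitrogen changes: removing the tert-butoxycarbonyl altogether stayed within the scatter, whereas exchanging tert-butoxy for dimethylamino on the carbonyl carbon, and adding dimethylcarbamoyl to the bare amine, gave modest gains. For the measured compounds named here, none of the measured steps involves a sulfonyl group, so the direction is uncertain; the expectation is a modest rise in number in this assay toward where compound 1 stands, i.e. a 2.5-fold higher number from compound 3 to compound 4 (0.40 log units; beyond the scatter). Compound 4 is therefore estimated at 5 nM, with a range from 1.5 nM to 20 nM.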

Compound 4, half-maximal inhibitory concentration: 2 nM
Beside the measured number, compound 4's estimate is 2.5-fold (0.40 log units) above it; the measured number falls inside the stated range.
By their numbers in this assay, from the lowest: compounds 3 and 4 (each within the scatter of the next); then compounds 1 and 2 (each within the scatter of the next).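

In this assay methylsulfonyl on the amine nitrogen takes the place of dimethylcarbamoyl with no change at the digits printed from compound 3 to compound 4 (within the scatter) as the step, so among the compounds shown a carbonyl on this nitrogen is not needed to keep the number of compound 3. Set against the bare amine, methylsulfonyl gives a 10-fold lower number from compound 2 to compound 4 (1.00 log units; beyond the scatter) as its step, and set against tert-butoxycarbonyl it gives a 5.0-fold lower number from compound 1 to compound 4 (0.70 log units; beyond the scatter) as its step, so two different groups now stand apart from compound 1 and compound 2 by the same margins. Nothing on hand explains why dimethylcarbamoyl and methylsulfonyl read alike here.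

Still open, as far as these compounds go, is whether acetyl or phenylsulfonyl on the same nitrogen would group with compound 3 and compound 4 or with compound 1 and compound 2. Also open, from the compounds shown here alone, is whether a carboxylic acid in place of the aminomethyl group would keep such numbers.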